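Swapping One Ring Arm on a Shared Core

A few compounds are considered here, and "the series" means these few. Any claim that something is new, unique, unknown or untested is made for them only; others in the source may bear on it.

Two measured entries share one core. Compound 1 `CCNC(=O)c1noc(-c2cc(C(C)C)c(O)cc2O)c1-c1cc(CNC(=O)CC)no1` shows "not determined" (no result reported) in a functional assay on A2780 cells (Homo sapiens) for inhibition (on this read-out lower numbers stand for stronger inhibition and higher numbers for weaker inhibition), that is, no result. Going by the values given here, compound 2 `CCNC(=O)c1noc(-c2cc(C(C)C)c(O)cc2O)c1-c1cc(CN(C)C)no1` gives 31 nM in this assay and holds the only number there, with compound 1 alongside it as an entry without one. Compound 3 `CCNC(=O)c1noc(-c2cc(C(C)C)c(O)cc2O)c1-c1cnn(C(C)C)c1` differs from compound 2 in a single place: 1-isopropyl-1H-pyrazol-4-yl in place of 3-((dimethylamino)methyl)-1,2-oxazol-5-yl on an aromatic carbon. Among the compounds with values here, no step between two measured compounds is available, so the size of this change cannot be read off from a neighbouring pair. The swap keeps one five-membered aromatic ring with 2 hetero atoms on the same aromatic carbon. The step from compound 2 to compound 3 is expected to be a 1.6-fold higher number from compound 2 to compound 3 (0.21 log units; within the scatter), a modest weakening that may not exceed the scatter. Compound 3 is estimated at 50 nM in this assay, with a range from 12 nM to 200 nM.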

Compound 3, half-maximal inhibitory concentration: 21 nM
The estimate for compound 3 lay 2.4-fold (0.38 log units) above the measured number; the measured number falls inside the stated range.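

In this assay the exchange gives a 1.5-fold lower number from compound 2 to compound 3 (0.17 log units; within the scatter) and so leaves the two compounds indistinguishable on this read-out. Going by these compounds alone, this is the first measured pair at this position, an aromatic carbon of the five-membered ring that also bears the ethylcarbamoyl group, and it shows that the 3-((dimethylamino)methyl)-1,2-oxazol-5-yl arm with its dimethylamino group is not needed for a value of this size, since the 1-isopropyl-1H-pyrazol-4-yl arm does as well within the scatter. Nothing given here explains this outcome.

One pair cannot show how much freedom this position allows overall. A phenyl ring, a morpholine or a carboxylic acid on the same carbon remains an open test, as each would show whether other kinds of arm are tolerated here too.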